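The compounds below may be only part of what the source reports. "The series", "measured", "known", "first", "only" and "open" are said of these compounds alone.

Measured in a functional assay on HepG2 cells (Homo sapiens) for antiproliferative activity, read by MTT assay; a lower number here means a stronger inhibitor, a higher number a weaker inhibitor:
Compound 1 `CC1(C)CCc2cc(C(=O)/C=C/c3ccc(OCc4cn(-c5ccc(Cl)cc5)nn4)cc3)c(O)cc2O1`: "not active" (no number reported)
Compound 2 `CC(=O)c1ccc(-n2cc(COc3ccc(/C=C/C(=O)c4cc5c(cc4O)OC(C)(C)CC5)cc3)nn2)cc1`: "not active" (no number reported)
Compound 3 `CC1(C)CCc2cc(C(=O)/C=C/c3ccc(OCc4cn(Cc5ccc([N+](=O)[O-])cc5)nn4)cc3)c(O)cc2O1`: 109000 nM

Compound 3 is the only one of these with a number, and at 109000 nM compound 3 counts as a weak inhibitor. Compound 4 `CCCCCCCCn1cc(COc2ccc(/C=C/C(=O)c3cc4c(cc3O)OC(C)(C)CC4)cc2)nn1` keeps the core of compound 3 and changes one group: heptyl in place of 4-nitrophenyl on a saturated chain carbon bound to an aromatic nitrogen. In words, this is heptyl in place of 4-nitrophenyl on a saturated chain carbon bound to an aromatic nitrogen. Among the measured compounds shown here, no measured pair shows what such a swap does, so only a modest gain in strength is expected, and a result without a number, as with compound 1 and compound 2, remains possible. The expected change is a 1.8-fold lower number from compound 3 to compound 4 (0.26 log units; within the scatter). Compound 4 is estimated at 60000 nM, in an expected range of 15000 nM to 200000 nM.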

Compound 4, half-maximal inhibitory concentration: 127000 nM
Beside the measured number, compound 4's estimate is 2.1-fold (0.33 log units) below it; the measured number falls inside the stated range.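

In this assay, heptyl in place of 4-nitrophenyl on a saturated chain carbon bound to an aromatic nitrogen gives a 1.2-fold higher number from compound 3 to compound 4 (0.07 log units; within the scatter) and so leaves the reading effectively unchanged. A ringed group carrying nitro and a plain carbon chain therefore cannot be told apart at this position. Nothing measured here accounts for this. Going by these compounds, whether an amine, a carboxylic acid or a shorter chain such as ethyl in this place would give a different number remains open. So does whether any group here can yield a strong inhibitor.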